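A Methyl Removed from Compound 1

A few compounds are considered here, and "the series" means these few. Any claim that something is new, unique, unknown or untested is made for them only; others in the source may bear on it.

Of the compounds shown here, two have been measured in a functional assay on the whole organism (Mus musculus) for inhibition, at a dose of 150 mg/kg by the oral route; a lower number here means less inhibition, a higher number more inhibition at the dose given (going by the name of the read-out). Compound 1 `Cc1coc2ccc(S(=O)(=O)NC(=O)Nc3ccc(Cl)cc3)cc12` gives 44% in this assay, and compound 2 `O=C(Nc1ccc(Br)cc1)NS(=O)(=O)c1cc2ccccc2o1` gives 48%. Compound 1 has the lower of the two numbers, yet compound 2 lies within the usual scatter of it, so the two cannot be put in order. Within the data shown here, no pair of measured compounds differs in a single place, so no measured step is known.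

Compound 3 `O=C(Nc1ccc(Cl)cc1)NS(=O)(=O)c1ccc2occc2c1` has not yet been measured. It differs from compound 1 in one place: hydrogen in place of methyl on an aromatic carbon. Among the measured compounds shown here, nothing among the measured compounds shows what such a change does here, so the expectation rests on the measured values alone. Compound 1 shows 44% and compound 2 shows 48% while differing in several places, which suggests that a single small change moves the number little. The expected step is therefore a number 2 percentage points lower from compound 1 to compound 3 (within the scatter), nothing beyond the scatter in either direction. Compound 3 is expected to give about 42% in this assay, within a range from 25% to 60%.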

Compound 3, a percentage reported as inhibition, in the whole organism at one dose (the size of the read-out at that dose, not a potency): 100%
For compound 3 the middle estimate is 58 percentage points below the measured one, outside the stated range (above it).
By their numbers in this assay, from the lowest: compounds 1 and 2 (each within the scatter of the next); then compound 3.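

Replacing methyl with hydrogen on the aromatic carbon two ring bonds from the ring oxygen gives, in this assay, a number 56 percentage points higher from compound 1 to compound 3 (beyond the scatter) at the single oral dose used. Compounds 1 and 2 differ in several places and lie within the scatter of each other, so they gave no view of any single position; this pair shows that the loss of one carbon at this place is enough to change the read-out by far more than the scatter. With hydrogen there, compound 3 gives 100% at that dose, a size of effect and not a potency, and no measurement at hand bears on why the number moves so far.

Only methyl and hydrogen are shown at this place, so it remains open whether an ethyl group, a methoxy group or a chlorine atom there would give a number nearer to that of compound 1 or to that of compound 3. As far as these compounds go, it also remains open whether the same step would appear with bromine in place of the chlorine on the other aromatic ring, or at other doses.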